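A few compounds are considered here, and "the series" means these few. Any claim that something is new, unique, unknown or untested is made for them only; others in the source may bear on it.

Measured compounds in a functional assay on HepG2 cells (Homo sapiens) for antiproliferative activity, read by CCK-8 assay, with a stated time of 72 h, tested at 8 uM; a lower number here means a weaker effect, a higher number a stronger effect of the compound at the concentration tested:
compound 1 `CN1CCN(c2nc(Cl)nc3c2ncn3Cc2ccc(C(=O)Nc3ccccc3N)cc2)CC1` — 75%
compound 2 `Nc1ccccc1NC(=O)c1ccc(Cn2cnc3c(Nc4ccccc4)nc(Cl)nc32)cc1` — 74.8%
compound 3 `Nc1ccccc1NC(=O)c1ccc(Cn2cnc3c(Nc4ccc(-c5ccccn5)cc4)nc(Cl)nc32)cc1` — 41.2%

Compound 3 stands lowest of the three numbers in this assay. The step of a number 0.2 percentage points lower from compound 1 to compound 2 (within the scatter) lies within the scatter, so compounds 1 and 2 are not distinguished; the step of a number 33.6 percentage points lower from compound 2 to compound 3 (beyond the scatter) is the only one beyond the scatter in the set.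

Compound 4 `Nc1ccccc1NC(=O)c1ccc(Cn2cnc3c(Nc4cccc(OC(F)(F)F)c4)nc(Cl)nc32)cc1` differs from compound 3 as follows: 3-(trifluoromethoxy)phenyl in place of 4-(pyridin-2-yl)phenyl on a nitrogen on an aromatic ring. Going by the values given here, the one measured step that bears on this change is a number 33.6 percentage points lower from compound 2 to compound 3 (beyond the scatter), which shows that the pyridin-2-yl group on the anilino ring carries a large loss; compound 4 removes that group. Among the compounds with values here, no measured step covers a trifluoromethoxy group on the anilino ring, so its own contribution is unknown. Removing the pyridin-2-yl group is expected to recover part of the loss, giving compound 4 an estimated step of a number 18.8 percentage points higher from compound 3 to compound 4 (beyond the scatter) upward in this assay. Compound 4 is therefore expected to reach 60% in this assay, within 35% to 85%.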

Compound 4, a percentage reported as inhibition, at one concentration (the size of the read-out at that concentration, not a potency): 31.2%
Beside the measured number, compound 4's estimate is 28.8 percentage points above it; the measured number lies below the stated range.
By their numbers in this assay, from the lowest: compounds 4 and 3 (each within the scatter of the next); then compounds 2 and 1 (each within the scatter of the next).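

In this assay, 3-(trifluoromethoxy)phenyl in place of 4-(pyridin-2-yl)phenyl on the nitrogen gives a number 10 percentage points lower from compound 3 to compound 4 (within the scatter) and so does not separate the two groups. Trifluoromethoxy in place of hydrogen on an aromatic carbon gives a number 43.6 percentage points lower from compound 2 to compound 4 (beyond the scatter) and (3-(trifluoromethoxy)phenyl)amino in place of 4-methylpiperazin-1-yl gives a number 43.8 percentage points lower from compound 1 to compound 4 (beyond the scatter), so the large drop at this position now appears with two different substituents rather than with pyridin-2-yl alone. No measured property of these compounds is available to explain this drop.

As far as these compounds go, whether any substituent on the anilino ring brings such a drop remains open. A methyl group, a primary amine or a carboxylic acid in place of hydrogen on that ring would show whether the read-out of compound 2 at 74.8% can be kept.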